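This account rests on a few compounds, and the source may have more. Where it says the series, first, only, none or still open, it means among the compounds named here.

The measured compounds:
Compound 1 `CCN1CCN(C[C@H]2CN(c3ccc(-n4cc(-c5ccccn5)cn4)c(F)c3)C(=O)O2)CC1` gives 99 ug/mL in an ADME assay on L02 cells (Homo sapiens) for cytotoxicity, read by MTT assay, with a stated time of 48 h; on this read-out higher numbers stand for weaker inhibition and lower numbers for stronger inhibition.
Compound 2 `O=C1O[C@@H](CN2CCCCC2)CN1c1ccc(-n2cc(-c3ccccn3)cn2)c(F)c1` gives only the limit > 400 ug/mL in this assay.
Compound 3 `O=CNC[C@H]1CN(c2ccc(-n3cc(-c4ccccn4)cn3)c(F)c2)C(=O)O1` gives only the limit > 400 ug/mL in this assay.

For the measured compounds named here, compound 1 thus stands as the only number obtained; the other two values are limits. Compound 4 `CNC(=O)[C@H]1CN(c2ccc(-n3cc(-c4ccccn4)cn3)c(F)c2)C(=O)O1` differs from compound 1 by methylcarbamoyl in place of (4-ethylpiperazin-1-yl)methyl on a saturated ring carbon. Going by the values given here, the steps that bear on this change are an at least 4.0-fold higher number from compound 1 to compound 2 (0.60 log units; beyond the scatter) and an at least 4.0-fold higher number from compound 1 to compound 3 (0.60 log units; beyond the scatter), both of which remove the 4-ethylpiperazin-1-yl group and both of which reach (the limit of > 400 ug/mL in this assay, at which 2 of the 3 values shown sit). Compound 4 also loses that group, so a step of at least comparable size toward weaker inhibition is expected. Compound 4 is therefore estimated at 400 ug/mL (range 150 ug/mL to 1000 ug/mL). This estimate means an expected step of a 4.0-fold higher number from compound 1 to compound 4 (0.61 log units; beyond the scatter), most likely reported only as a limit.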

Compound 4, half-maximal inhibitory concentration: 217 ug/mL
For compound 4 the middle estimate is 1.8-fold (0.27 log units) above the measured one, within the range that was stated.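

Methylcarbamoyl in place of (4-ethylpiperazin-1-yl)methyl on this saturated ring carbon gives a 2.2-fold higher number from compound 1 to compound 4 (0.34 log units; beyond the scatter) in this assay, so losing the 4-ethylpiperazin-1-yl group here still leaves a readable number rather than a limit. The comparisons with the two other compounds give only floors: an at least 1.8-fold lower number from compound 3 to compound 4 (0.26 log units; that floor lies within the scatter), and an at least 1.8-fold lower number from compound 2 to compound 4 (0.26 log units; that floor lies within the scatter). These two comparisons rest on limits, not numbers: the limit of > 400 ug/mL in this assay, at which 2 of the 4 values shown sit.

On these data alone, it remains open whether a carboxylic acid or an amide with a longer chain on this ring carbon would give a similar number. As far as these compounds go, it also remains open how a 4-ethylpiperazin-1-yl amide would read here.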